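From ethylamino to methylamino: a small step without a baseline

The source may hold more compounds than are shown below. What is called first, only, known or untested is meant among the compounds shown, and "the series" means these compounds.

Within the data shown here, in an ADME assay on J774.A1 cells (Mus musculus) for inhibition, read by MTT assay, with a stated time of 72 h (on this read-out lower numbers stand for an effect already at smaller amounts and higher numbers for an effect only at larger amounts of compound), compound 1 `CNc1nc(NCc2ccccc2)nc2ccccc12` gives 15000 nM and is the only compound with a number so far. Compound 2 `CCNc1nc(NC)c2ccccc2n1` has no place on that scale, since its entry reads "not determined" (no result reported) and no single number exists for it. Compound 3 `CNc1nc(NC)c2ccccc2n1` still awaits measurement. The change hydrogen in place of methyl on a saturated chain carbon bound to a nitrogen on an aromatic ring puts hydrogen in place of methyl on a saturated chain carbon bound to a nitrogen on an aromatic ring, turning ethylamino to methylamino. Among the measured compounds shown here, no measured step shows what such a change does in this assay and no baseline exists to apply one to. The expectation is therefore for a shift no larger than the usual scatter, with no preferred direction. For the measured compounds named here, the only number to lean on is that of compound 1 at 15000 nM and this leaves the estimate loose, leaning towards larger amounts with wide margins. For compound 3 the expected value is 40000 nM with an estimated range from 12000 nM to 120000 nM in this assay as the reading to be tested.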

Compound 3, half-maximal effective concentration: > 133000 nM
Compound 3 gave a limit, no number; the forecaster's own chance of this, stated with the estimate: 35%; middle value at least 3.3-fold (0.52 log units) away from the limit.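

In this assay compound 3 gives > 133000 nM, which is a limit of the assay and not a number. Even so, it yields the first readable step on this scale, an at least 8.8-fold higher number from compound 1 to compound 3 (0.94 log units; beyond the scatter), and in this step the phenyl on a saturated chain carbon gives way to hydrogen, so that the position now shows a change that reaches beyond the usual scatter. How large the step really is stays unknown, as the reading for compound 3 ends at the limit of the assay: the limit of > 133000 nM in this assay, at which 1 of the 3 values shown sits.

Going by these compounds, the step from ethylamino to methylamino between compound 2 and compound 3 cannot be read, as compound 2 has no number, so whether ethyl and methyl differ on this scale remains open. The compounds shown also do not tell whether a propyl chain, or an amine or a carboxylic acid in place of the phenyl on that saturated chain carbon, would give a number inside the range of this assay.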